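The source may report more compounds than this note shows. Statements on the series, on what has been measured and on what is new or still open speak of the compounds shown alone.

Compound 1 `CC(C)(C)c1ccc(S(=O)(=O)Nc2ccc(Cl)cc2-c2ncccc2CN)cc1` gives 3160 nM in a functional assay on isolated protein for antagonist activity at C-C chemokine receptor type 9 (Homo sapiens), read by calcium flux, with a stated time of 10 min; on this read-out higher numbers stand for weaker inhibition and lower numbers for stronger inhibition. For the measured compounds named here, compound 2 `CC(C)(C)c1ccc(S(=O)(=O)Nc2ccc(Cl)cc2-c2nccc(C(N)=O)c2O)cc1` gives 52 nM in this assay, and the step of a 61-fold lower number from compound 1 to compound 2 (1.78 log units; beyond the scatter) is the only measured step in this set. Compound 2 thus stands lowest of the two measured compounds, with compound 1 as its nearest neighbour. Compound 3 `CC(C)(C)c1ccc(S(=O)(=O)Nc2ccc(Cl)cc2-c2nccc(CO)c2O)cc1` differs from compound 2 by hydroxymethyl in place of carbamoyl on an aromatic carbon. Going by the values given here, no measured step exchanges these two groups. Among the compounds with values here, the one step, a 61-fold lower number from compound 1 to compound 2 (1.78 log units; beyond the scatter), rebuilt the substituted ring as a whole and bears only loosely on this change; it does show that the groups on this ring move the number strongly. Compound 3 keeps the hydroxy group of compound 2 while the carbamoyl gives way to hydroxymethyl. A modest weakening is expected, a 2.9-fold higher number from compound 2 to compound 3 (0.46 log units; beyond the scatter). Compound 3 is therefore estimated to give about 150 nM in this assay, with a range from 40 nM to 600 nM.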

Compound 3, half-maximal inhibitory concentration: 8.7 nM
Beside the measured number, compound 3's estimate is 17-fold (1.24 log units) above it; measured number below the stated range.
By their numbers in this assay, from the lowest: compound 3; then compound 2; then compound 1.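

In this assay, hydroxymethyl in place of carbamoyl, on an aromatic carbon ortho to a hydroxy group and opposite the ring nitrogen, gives a 6.0-fold lower number from compound 2 to compound 3 (0.78 log units; beyond the scatter), so carbamoyl is not required at this position for a low number. The two groups carry the same printed count of hydrogen-bond donors and acceptors, so that count does not separate them, and the wider replacement of the whole group gives a 360-fold lower number from compound 1 to compound 3 (2.56 log units; beyond the scatter). No measurement here explains the difference between carbamoyl and hydroxymethyl.

The compounds shown leave open how a carboxylic acid, a methoxymethyl group or a longer chain such as hydroxyethyl would fare on this carbon. They also leave open whether the result with hydroxymethyl holds without the hydroxy group, which compound 2 and compound 3 share.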